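Bromine position on the phenyl group: compound 2 to compound 3

The compounds below may be only part of what the source reports. "The series", "measured", "known", "first", "only" and "open" are said of these compounds alone.

In a functional assay (a lower number here means a stronger inhibitor, a higher number a weaker inhibitor), compound 1 (`CC(C)=CCOc1ccc2c(c1)OC(c1ccccc1)CC2=O`) gives 6070 nM and compound 2 (`CC(C)=CCOc1ccc2c(c1)OC(c1ccccc1Br)CC2=O`) gives 3180 nM. Among the compounds with values here, these are the only two numbers measured so far, and they lie within the scatter of each other, so compound 2 stands level with compound 1.

Compound 3 (`CC(C)=CCOc1ccc2c(c1)OC(c1ccc(Br)cc1)CC2=O`) keeps the shared core and has 4-bromophenyl in place of 2-bromophenyl on a saturated ring carbon, next to the ring oxygen. The computed difference reads: 4-bromophenyl in place of 2-bromophenyl on a saturated ring carbon.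

Within the data shown here, one measured step bears on this change: a 1.9-fold lower number from compound 1 to compound 2 (0.28 log units; within the scatter), for bromo in place of hydrogen on an aromatic carbon. That step stays within the scatter. Among the measured compounds shown here, no measured compound carries the 4-bromophenyl group, so the data give no direct guide to this position. No step beyond the scatter is therefore expected in this assay, and neither direction is clearly favoured. The estimated change is a 1.3-fold higher number from compound 2 to compound 3 (0.10 log units; within the scatter). The expected value for compound 3 is 4000 nM, with an estimated range of 1500 nM to 10000 nM.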

Compound 3, half-maximal inhibitory concentration: 8120 nM
Beside the measured number, compound 3's estimate is 2.0-fold (0.31 log units) below it; the measured number falls inside the stated range.
By their numbers in this assay, from the lowest: compounds 2, 1 and 3 (each within the scatter of the next, the first and the last beyond it).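

In this assay, within the data shown here, moving the bromine gives the first step that lies beyond the scatter: a 2.6-fold higher number from compound 2 to compound 3 (0.41 log units; beyond the scatter) for 4-bromophenyl in place of 2-bromophenyl on a saturated ring carbon, so the position of the bromine on this phenyl group does register in the read-out, though only modestly. Against the unsubstituted phenyl group, the other bromo compound gives a 1.3-fold higher number from compound 1 to compound 3 (0.13 log units; within the scatter) and so does not separate from it, which means that only the two bromo isomers are distinguished from each other, while neither is distinguished from compound 1. Nothing available explains the gap between the two isomers.

As far as these compounds go, whether the same gap appears with another group on the phenyl ring, such as chloro, methoxy, an amine or a carboxylic acid, remains open. Also open, from the compounds shown here alone, is whether a longer chain in place of the ether side chain of the shared core would change the difference between 2-bromophenyl and 4-bromophenyl seen in this assay with these compounds.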